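This account rests on a few compounds, and the source may have more. Where it says the series, first, only, none or still open, it means among the compounds named here.

Measured compounds in a functional assay on MDA-MB-231 cells (Homo sapiens) for cytotoxicity, read by MTT assay, with a stated time of 48 h; a lower number here means a stronger inhibitor, a higher number a weaker inhibitor:
Compound 1, `O=C(NCCCCC(c1ccc(F)cc1)c1ccc(F)cc1)Nc1ccc(I)cc1`, where compound 1 gives 11800 nM.
Compound 2, `CC(=O)Nc1ccc(NC(=O)NCCCCC(c2ccc(F)cc2)c2ccc(F)cc2)cc1`, where compound 2 reaches only the limit of this assay, > 20000 nM.
Compound 3, `O=C(NCCCCC(c1ccc(F)cc1)c1ccc(F)cc1)Nc1cccc(C(F)(F)F)c1`, where compound 3 gives 3380 nM.

Of the two numbers shown in this assay, compound 1 stands at the highest; its nearest neighbour is compound 3, with a 3.5-fold lower number from compound 1 to compound 3 (0.54 log units; beyond the scatter). Compound 2 sits at a limit and gives no number (the limit of > 20000 nM in this assay, at which 1 of the 3 values shown sits).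

Compound 4, `O=C(NCCCCC(c1ccc(F)cc1)c1ccc(F)cc1)Nc1ccc(Cl)c(C(F)(F)F)c1`, differs from compound 1 in one place: 4-chloro-3-(trifluoromethyl)phenyl in place of 4-iodophenyl on an amide-type nitrogen. Within the data shown here, two measured steps bear on this change. The step of a 3.5-fold lower number from compound 1 to compound 3 (0.54 log units; beyond the scatter) puts a 3-(trifluoromethyl)phenyl in place of 4-iodophenyl, and an at least 5.9-fold lower number from compound 2 to compound 3 (0.77 log units; beyond the scatter) reaches the same 3-(trifluoromethyl)phenyl from the acetamido side. Among the measured compounds shown here, compound 4 carries that trifluoromethyl together with a chlorine, and no measured step tests the chlorine on its own. The account therefore expects in this assay a step of about the size seen for compound 3, a lower number: a 4.7-fold lower number from compound 1 to compound 4 (0.67 log units; beyond the scatter) is the expected step. Compound 4 is estimated at 2500 nM, within 800 nM to 8000 nM.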

Compound 4, half-maximal inhibitory concentration: 3150 nM
Estimate against measurement, compound 4: 1.3-fold (0.10 log units) below; low and high end bracket the measured number.
By their numbers in this assay, from the lowest: compounds 4 and 3 (each within the scatter of the next); then compound 1. At a limit, above all of these: compound 2.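

Chloro in place of hydrogen on an aromatic carbon, a change no earlier pair isolated, gives in this assay a 1.1-fold lower number from compound 3 to compound 4 (0.03 log units; within the scatter), so the chlorine adds nothing readable to the trifluoromethyl already present. The move from 4-iodophenyl to 4-chloro-3-(trifluoromethyl)phenyl on the amide-type nitrogen gives a 3.7-fold lower number from compound 1 to compound 4 (0.57 log units; beyond the scatter), and this step therefore rests on what compound 4 shares with compound 3. Measured from the acetamido side, the step is an at least 6.3-fold lower number from compound 2 to compound 4 (0.80 log units; beyond the scatter), which is only a floor, since compound 2 stands at a limit: the limit of > 20000 nM in this assay, at which 1 of the 4 values shown sits.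

The compounds shown leave open whether a nitrile or an amine in place of the chlorine would move the number. They also leave open whether a longer chain between the urea and the two fluorophenyl rings would do so.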